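The compounds below may be only part of what the source reports. "The series", "measured", "known", "first", "only" and "open" are said of these compounds alone.

Among the compounds with values here, compound 1, `COc1ccc(OC)c(C2=C(c3cc(OC)c(OC)c(OC)c3)C(=O)CC2O[SiH2]C(C)(C)C)c1`, is the one member of this set that returns a number rather than a limit. In an ADME assay on L132 cells (Homo sapiens) for cytotoxicity, read by MTT assay, with a stated time of 72 h (on this read-out lower numbers stand for stronger inhibition and higher numbers for weaker inhibition), compound 1 gives 100 ug/mL. Compound 2, `COc1ccc(C2=C(c3cc(OC)c(OC)c(OC)c3)CC(O)C2=O)cc1[N+](=O)[O-]`, stops at a limit of the assay: in this assay compound 2 gives > 100 ug/mL. Compound 3, `COc1ccc(C2=C(c3cc(OC)c(OC)c(OC)c3)CC(O[SiH2]C(C)(C)C)C2=O)cc1[N+](=O)[O-]`, also stops at a limit, giving > 100 ug/mL in this assay. The set thus shows (the limit of > 100 ug/mL in this assay, at which 2 of the 3 values shown sit). The difference between the core of compound 1 and that of compound 3 is not broken down here. From compound 3 to compound 2 the change is a hydrogen atom in place of a group of 5 heavy atoms (4 carbon, 1 silicon; no ring), on an oxygen on a saturated carbon, and it gives a step that the two limits leave unreadable from compound 3 to compound 2. Compound 4, `COc1ccc(OC)c(C2=C(c3cc(OC)c(OC)c(OC)c3)C(=O)CC2O)c1`, is not yet measured. It differs from compound 1 by a hydrogen atom in place of a group of 5 heavy atoms (4 carbon, 1 silicon; no ring), on an oxygen on a saturated carbon, the same change, at the same place, as that from compound 3 to compound 2. Because the earlier step is a step that the two limits leave unreadable from compound 3 to compound 2, it offers no size to carry over, and compound 1 at 100 ug/mL is the only anchor. The expected step is a 1.1-fold higher number from compound 1 to compound 4 (0.04 log units; within the scatter), within the usual scatter. In this assay compound 4 is expected at 110 ug/mL, with a range from 50 ug/mL to 250 ug/mL and a real chance that only a limit is reported.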

Compound 4, half-maximal inhibitory concentration: > 100 ug/mL
Compound 4 gave a limit, no number (the forecaster's own chance of this, stated with the estimate: 55%); the middle value is on the limit's open side.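

On the core of compound 1, replacing the group of 5 heavy atoms (4 carbon, 1 silicon; no ring) with hydrogen, on an oxygen on a saturated carbon, gives a number no lower from compound 1 to compound 4 (the limit leaves the size open). This shows only a direction on one core: the steps in this assay cannot be read for size, so nothing shows that the change has the same effect on the core of compound 1 and the core of compound 3. Neither step can be compared with the other, because the values gather at one limit of the assay: the limit of > 100 ug/mL in this assay, at which 3 of the 4 values shown sit.

The compounds shown leave open how the read-out would respond on either core if an amine or an acetyl ester stood in place of the hydroxyl group on that saturated carbon. They also leave open what numbers compound 2, compound 3 and compound 4 would take, since each stops at a limit rather than a number.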